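Shortening an Alkyl Chain on the Shared Core

The source may report more compounds than this note shows. Statements on the series, on what has been measured and on what is new or still open speak of the compounds shown alone.

Compound 1 `CCCCNC(=O)N1CC1C#N` has been measured in a functional assay on RPMI-8226 cells (Homo sapiens) for inhibition (on this read-out lower numbers stand for stronger inhibition and higher numbers for weaker inhibition), where compound 1 gives 17000 nM. Compound 2 `N#CC1CN1C(=O)Nc1ccc([N+](=O)[O-])cc1` gives 8600 nM in this assay. Going by the values given here, these two values lie within the usual scatter of each other, so the numbers so far do not separate compound 1 from compound 2. Compound 3 `CNC(=O)N1CC1C#N` has not yet been measured. It differs from compound 1 in one place: hydrogen in place of propyl on a saturated chain carbon bound to an amide-type nitrogen. Among the compounds with values here, no pair of measured compounds shows this change, so the size of the step cannot be read from a measured pair; a small step toward weaker inhibition, or none beyond the scatter, is expected. Because compound 1 gives 17000 nM, compound 3 is expected to remain weak, and the expected step is a 1.5-fold higher number from compound 1 to compound 3 (0.17 log units; within the scatter). Compound 3 is estimated at 25000 nM, with a range from 8000 nM to 80000 nM.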

Compound 3, half-maximal inhibitory concentration: 26000 nM
Compound 3: middle estimate off by 1.0-fold (0.02 log units), on the low side; measured number inside the range.
By their numbers in this assay, from the lowest: compounds 2, 1 and 3 (each within the scatter of the next, the first and the last beyond it).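

With compound 3 the change finally has a measured pair: in this assay, hydrogen in place of propyl on a saturated chain carbon bound to an amide-type nitrogen gives a 1.5-fold higher number from compound 1 to compound 3 (0.18 log units; within the scatter). Read one bond further out, this is butyl to methyl, so at this position on the shared core the two chains are not separated by this read-out, and the butyl chain of compound 1 shows no measurable gain over the methyl of compound 3. Nothing available here bears on why these numbers stand where they do.

From the compounds shown here alone, whether a longer chain, such as octyl, would move the number beyond the scatter remains open. The same holds for an amine or a carboxylic acid at the end of the chain.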